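Three Measured Compounds and an Expected Fourth

The source may hold more compounds than are shown below. What is called first, only, known or untested is meant among the compounds shown, and "the series" means these compounds.

Three compounds have been measured in a functional assay on SNB-19 cells (Homo sapiens) for inhibition, read by sulforhodamine B assay, with a stated time of 48 h; on this read-out lower numbers stand for stronger inhibition of growth and higher numbers for weaker inhibition of growth:
compound 1 `COc1cc(-c2nn(-c3cccc(NC(=O)Nc4cc(C(F)(F)F)cc(C(F)(F)F)c4)c3)cc2-c2ccncc2)ccc1Cl` gives 711 nM
compound 2 `COc1cc(-c2nn(-c3cccc(NC(=O)Nc4ccc(Cl)c(Cl)c4)c3)cc2-c2ccncc2)ccc1Cl` gives 1720 nM
compound 3 `O=C(Nc1cccc(-n2cc(-c3ccncc3)c(-c3ccc(Cl)c(O)c3)n2)c1)Nc1ccc(Cl)c(Cl)c1` gives 1460 nM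

Compound 2 carries the highest number of the three; compound 3 sits within the scatter of it, while compound 1 lies beyond the scatter with a lower number. Going by the values given here, the only single-point step among them, a 1.2-fold lower number from compound 2 to compound 3 (0.07 log units; within the scatter), concerns a different place in the structure. Compound 4 `COc1cc(-c2nn(-c3cccc(NC(=O)c4ccc(Cl)c(C(F)(F)F)c4)c3)cc2-c2ccncc2)ccc1Cl` differs from compound 2 by 4-chloro-3-(trifluoromethyl)phenyl in place of (3,4-dichlorophenyl)amino on a carbonyl carbon. Among the compounds with values here, no measured step shows this change, so the expectation rests only on the spread of the three numbers seen in this assay. A modest step is expected, a 1.2-fold higher number from compound 2 to compound 4 (0.07 log units; within the scatter), with wide uncertainty. Compound 4 is therefore estimated at 2000 nM, in a range from 600 nM to 7000 nM.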

Compound 4, concentration for 50% growth inhibition: 8680 nM
Compound 4: middle estimate off by 4.3-fold (0.64 log units), on the low side, and the stated range ends below it.
By their numbers in this assay, from the lowest: compound 1; then compounds 3 and 2 (each within the scatter of the next); then compound 4.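

At this carbonyl carbon, this assay records a 5.0-fold higher number from compound 2 to compound 4 (0.70 log units; beyond the scatter), so this position responds to the change, which the earlier step at a different place could not show. The change removes the amino nitrogen with its hydrogen-bond donor and also alters the ring's groups, and this single step cannot separate those two differences. Nothing available explains the step. Still open, on these data alone, is how 4-chloro-3-(trifluoromethyl)phenyl would behave when attached through an amino nitrogen. A methylene linker in that nitrogen's place also remains untested among these compounds.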